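Swapping a hydroxyethyl sulfanyl arm for an anilino group

This account rests on a few compounds, and the source may have more. Where it says the series, first, only, none or still open, it means among the compounds named here.

In a functional assay on the whole organism with Mus musculus as the target (on this read-out higher numbers stand for an effect only at larger amounts of compound and lower numbers for an effect already at smaller amounts), compound 1 `Cc1c(C)c2c(c(C)c1N)CC(C)(CSc1ccccc1)O2` gives 24.7 mg/kg and compound 2 `Cc1c(C)c2c(c(C)c1N)CC(C)(CSc1ccc(F)cc1)O2` gives 17.9 mg/kg, and the fluoro swap between them is a 1.4-fold lower number from compound 1 to compound 2 (0.14 log units; within the scatter). Compound 3 `Cc1c(C)c2c(c(C)c1N)CC(C)(CSCCO)O2` stands at > 50 mg/kg, which is a limit of the assay and not a number. Compound 4 `Cc1c(C)c2c(c(C)c1N)CC(C)(CNc1ccccc1)O2` differs from it as follows: anilino in place of (2-hydroxyethyl)sulfanyl on a saturated chain carbon bound to a saturated ring carbon. This restores an aromatic ring, as carried by compound 1 and compound 2. Among the measured compounds shown here, two measured steps bear on this, both losing that ring: an at least 2.0-fold higher number from compound 1 to compound 3 (0.30 log units; that floor lies within the scatter) and an at least 2.7-fold higher number from compound 2 to compound 3 (0.44 log units; beyond the scatter). A partial reversal is therefore expected, an estimated step of an at least 2.0-fold lower number from compound 3 to compound 4 (0.30 log units; that floor lies within the scatter) towards lower numbers. Compound 4 is expected at 25 mg/kg, within an estimated range of 11 mg/kg to 50 mg/kg.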

Compound 4, dose for 50% inhibition: 15.7 mg/kg
Compound 4: middle estimate off by 1.6-fold (0.20 log units), on the high side; low and high end bracket the measured number.
By their numbers in this assay, from the lowest: compounds 4, 2 and 1 (each within the scatter of the next). At a limit, above all of these: compound 3.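

In this assay, anilino on this saturated chain carbon gives an at least 3.1-fold lower number from compound 3 to compound 4 (0.50 log units; beyond the scatter), the first step shown that gains an aromatic ring here instead of losing one. Compound 3 stands at a limit and not a number, so that step is only a floor: the limit of > 50 mg/kg in this assay, at which 1 of the 4 values shown sits. With the aromatic ring kept, exchanging sulfur for nitrogen in the link gives a 1.6-fold lower number from compound 1 to compound 4 (0.20 log units; within the scatter), so this read-out does not separate the two links. The compounds shown leave open whether the ring needs to be aromatic, as a cyclohexylamino group would show, and whether a phenoxy group would match anilino and phenylsulfanyl.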